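A few compounds are considered here, and "the series" means these few. Any claim that something is new, unique, unknown or untested is made for them only; others in the source may bear on it.

The measured compounds and their values in this cytotoxicity assay:

compound 1 `COC(=O)c1ccc(NCc2cncn2Cc2ccccc2Cl)cc1-c1ccccc1`: 10000 nM
compound 2 `O=C(c1ccc(NCc2cncn2Cc2ccc(-c3ccccc3)cc2)cc1-c1ccccc1)N1CCCCC1`: > 1000 nM
compound 3 `Cc1cccc(-c2cc(NCc3cncn3Cc3ccc(-c4ccccc4)cc3)ccc2-c2nc3ccccc3s2)c1C`: > 1000 nM

Among the measured compounds shown here, in a toxicity assay on NIH3T3 cells (Mus musculus) for cytotoxicity, read by resazurin assay (a higher number here means that more compound is needed for the effect, a lower number that less compound is needed), compound 1 gives 10000 nM, the only value here that is a definite number. For compound 2 the assay reports only a limit, > 1000 nM. For compound 3 likewise only a limit is reported, > 1000 nM. For the measured compounds named here, the measured picture therefore rests on (the limit of > 1000 nM in this assay, at which 2 of the 3 values shown sit), with compound 1 as the single fixed point, and no step between two measured compounds can be read from it.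

Compound 4 `COC(=O)c1ccc(NCc2cncn2Cc2ccc([N+](=O)[O-])cc2)cc1-c1ccccc1` has not yet been measured. Relative to compound 1 the change is 4-nitrophenyl in place of 2-chlorophenyl on a saturated chain carbon bound to an aromatic nitrogen, a swap of one substituted phenyl for another at the same place on the shared core. Going by the values given here, with no measured step to lean on, the expectation for no change at the digits printed from compound 1 to compound 4 (within the scatter) is a step no larger than the usual scatter, in either direction. Compound 4 is accordingly estimated at 10000 nM, with a plausible range from 3000 nM to 30000 nM.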

Compound 4, half-maximal effective concentration: > 10000 nM
Compound 4 ended at the assay's limit (the forecaster's own chance of this, stated with the estimate: 40%); the middle value lies on the limit itself.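

In this assay compound 4 gives > 10000 nM as its result, which is a limit of the assay and not a number. Among the compounds shown here, this provides the first step that can be read at this place, on a saturated chain carbon bound to an aromatic nitrogen: 4-nitrophenyl in place of 2-chlorophenyl gives a number no lower from compound 1 to compound 4 (the limit leaves the size open) as the reading. The swap brings in 2 hydrogen-bond acceptors where the leaving group had none and does not lower the number, but any rise stays hidden at the ceiling of the test: the limit of > 10000 nM in this assay, at which 1 of the 4 values shown sits.

The compounds shown leave open whether the choice of group or its place on the phenyl ring counts, since 2-chlorophenyl and 4-nitrophenyl differ in both. They also give no reading for an amine or a carboxylic acid on that ring.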